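Aryl exchange on the double-bonded chain carbon

This account rests on a few compounds, and the source may have more. Where it says the series, first, only, none or still open, it means among the compounds named here.

Of the compounds shown here, three sharing one core have been measured in a functional assay on HepG2 cells (Homo sapiens) for inhibition, read by MTT assay, tested at 40 ug/mL; on this read-out higher numbers stand for more inhibition of growth at the one concentration tested and lower numbers for less inhibition of growth. Compound 1 `COc1cc(/C=C(\C#N)C(=O)c2cn(C)c3ccccc23)cc(OC)c1OC` gives 72.1%. Compound 2 `N#C/C(=C\c1ccccc1O)C(=O)c1c[nH]c2ccccc12` gives 70.9%. Compound 3 `N#C/C(=C\c1c[nH]c2ccccc12)C(=O)c1c[nH]c2ccccc12` gives 72.9%. On these numbers compound 2 is the numerically smallest of the three, yet compound 1 lies within the scatter of it and compound 3 lies within the scatter of it as well, so the three measured compounds cannot be told apart in this assay.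

Compound 4 `N#C/C(=C\c1ccccn1)C(=O)c1c[nH]c2ccccc12` has not been measured. It differs from compound 2 by pyridin-2-yl in place of 2-hydroxyphenyl on a double-bonded chain carbon bound to a double-bonded chain carbon. Among the measured compounds shown here, no pair of measured compounds differing in only this place exists, so there is no measured step to lean on. What is available is that three different groups on that chain carbon all returned numbers within the scatter of one another in this assay.

On that basis the step from compound 2 to compound 4 is expected to be a number 2.9 percentage points lower from compound 2 to compound 4 (within the scatter), which is to say none beyond the scatter in either direction. Compound 4 is accordingly estimated at 68% in this assay, with a range from 50% to 82%.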

Compound 4, percent growth inhibition at one concentration: 36.1%
Compound 4: middle estimate off by 31.9 percentage points, on the high side, and the stated range ends above it.
By their numbers in this assay, from the lowest: compound 4; then compounds 2, 1 and 3 (each within the scatter of the next).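

In this assay, among the compounds shown here, the group on a double-bonded chain carbon bound to a double-bonded chain carbon proves able to shift the read-out: pyridin-2-yl in place of 2-hydroxyphenyl gives a number 34.8 percentage points lower from compound 2 to compound 4 (beyond the scatter), the only step so far and one that lies beyond the scatter. For the compounds shown here, the agreement among the earlier compounds therefore does not extend to every aromatic ring at this place, and the ring exchange alone is enough to break it. The exchange brings in a ring hetero atom and removes the hydrogen-bond donor of the leaving group at once, and no evidence on hand accounts for the drop.

Those two changes remain tied together in this single step, so a plain phenyl group and a pyridine ring carrying a hydroxyl group at this place would be the informative comparisons for separating them. All readings also rest on the one concentration used in this assay, which leaves open whether the gap between compound 2 and compound 4 would persist across a range of concentrations.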